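The source may report more compounds than this note shows. Statements on the series, on what has been measured and on what is new or still open speak of the compounds shown alone.

Going by the values given here, compound 2 `COc1ccc2nc(C)cc(OCC(=O)Nc3c(C)cccc3C)c2c1` is one of two compounds measured in a physicochemical assay for lipophilicity, read by HPLC, in phosphate buffer, measured as chromatographic lipophilicity, at pH 7.4; on this read-out lower numbers stand for lower lipophilicity and higher numbers for higher lipophilicity. In this assay compound 2 gives 4.55, the lower of the two numbers shown. Its only companion, compound 1 `Cc1cc(C)cc(NC(=O)COc2cc(C)nc3ccc(OCc4ccccc4)cc23)c1`, gives 7.03 in this assay, a value that lies higher, beyond the scatter of repeated measurements. Compound 3 `COc1ccc2nc(C)cc(OCC(=O)Nc3cccnc3)c2c1` has not yet been measured in this assay. It differs from compound 2 in one place: pyridin-3-yl in place of 2,6-dimethylphenyl on an amide-type nitrogen. Among the compounds with values here, the two compounds measured so far share no single-point step, so the size of this change is not known from the data. The pyridin-3-yl that enters is smaller than the 2,6-dimethylphenyl that leaves and brings one hydrogen-bond acceptor, so a downward step in this assay is expected, larger than the scatter, estimated as a number 2.25 log units lower from compound 2 to compound 3 (beyond the scatter). Compound 3 is accordingly expected to give about 2.3 in this assay, somewhere between 1.4 and 3.2.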

Compound 3, distribution coefficient: 2.46
Compound 3: middle estimate off by 0.16 log units, on the low side; the measured number falls inside the stated range.
By their numbers in this assay, from the lowest: compound 3; then compound 2; then compound 1.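

Going by these compounds alone, the exchange of 2,6-dimethylphenyl for pyridin-3-yl on an amide-type nitrogen gives the first single-point step in this assay: the read-out falls by a number 2.09 log units lower from compound 2 to compound 3 (beyond the scatter), a large change. Within the data shown here, the two earlier compounds could not show this, as they shared no such step. It shows that the group on this nitrogen alone can move the number far beyond the scatter while the rest of the molecule stays the same, though nothing measured here explains the size of the step.

The compounds shown leave open how much of the step goes with the two methyl groups and how much with the ring nitrogen, which a plain phenyl on the same nitrogen would help to separate. Also open, from the compounds shown here alone, is where pyridin-2-yl, pyridin-4-yl or a phenyl carrying an amine would fall on this read-out.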